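Swapping an anilino group for allylamino on a cytotoxic scaffold

The compounds below may be only part of what the source reports. "The series", "measured", "known", "first", "only" and "open" are said of these compounds alone.

The measured compounds, in a functional assay on CCRF-CEM cells (Homo sapiens) for cytotoxicity, read by resazurin assay, with a stated time of 48 h; a higher number here means a weaker inhibitor, a lower number a stronger inhibitor:

Compound 1 `CCOc1ccc(NC(=O)c2c(N)n[nH]c2Nc2ccccc2)cc1` gives 4470 nM.
Compound 2 `CCOc1ccc(-n2nnc3n[nH]c(NC)c3c2=O)cc1` gives 12400 nM.
Compound 3 `CCOc1ccc(NC(=O)CC#N)cc1` gives 14100 nM.

Compound 1 has the lowest number of the three, so it is the strongest inhibitor among them; its gap to compound 2 and its gap to compound 3 both lie beyond the scatter of repeated measurements, so that ranking can be trusted.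

Compound 4 `C=CCNc1[nH]nc(N)c1C(=O)Nc1ccc(OCC)cc1` has not been measured. It differs from compound 1 in one spot: allyl in place of phenyl on a nitrogen on an aromatic ring. Nothing else in the shared core changes.

Among the compounds with values here, no measured pair shows this exact change, so there is no comparable step to lean on. In this assay compound 4 is expected to give a number somewhat higher than compound 1, a step of the size a 1.5-fold higher number from compound 1 to compound 4 (0.16 log units; within the scatter), likely near the edge of the scatter rather than far beyond it. The estimate for compound 4 is 6500 nM, with a range from 2500 nM to 16000 nM.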

Compound 4, half-maximal inhibitory concentration: 6560 nM
Beside the measured number, compound 4's estimate is 1.0-fold (0.00 log units) below it; the range from low to high includes it.
By their numbers in this assay, from the lowest: compounds 1, 4, 2 and 3 (each within the scatter of the next, the first and the last beyond it).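

In this assay, replacing anilino with allylamino gives a 1.5-fold higher number from compound 1 to compound 4 (0.17 log units; within the scatter), so the two compounds cannot be told apart in this assay. This nitrogen on an aromatic ring therefore accepts an open allyl chain of 3 heavy atoms in place of a phenyl ring of 6 without a change that can be read, and on this evidence the aromatic ring is not required at this spot for the cytotoxicity seen in these cells. No evidence is available to explain why the two groups read alike.

The compounds shown leave open whether the double bond of the allyl group matters, which a saturated propyl chain would test. They also leave open how far this tolerance extends, for example to a larger benzyl group or to a plain amine with nothing attached.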